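An Added Isopropyl Group Tested Against Breast Cancer Cells

The compounds below may be only part of what the source reports. "The series", "measured", "known", "first", "only" and "open" are said of these compounds alone.

Compound 1 `Cc1ccc(-c2csc(NC(=O)COc3ccccc3)n2)cc1` is the starting point. In a functional assay on MDA-MB-468 cells (Homo sapiens) for cytotoxicity, read by MTT assay, with a stated time of 48 h (on this read-out higher numbers stand for weaker inhibition and lower numbers for stronger inhibition), compound 1 gives 54900 nM. Compound 2 `Cc1ccc(-c2csc(NC(=O)COc3ccccc3C(C)C)n2)cc1` differs from it by isopropyl in place of hydrogen on an aromatic carbon; in this assay compound 2 gives 55500 nM, so there is a 1.0-fold higher number from compound 1 to compound 2 (0.00 log units; within the scatter). Compound 3 `CC(C)c1ccccc1OCC(=O)Nc1nc(-c2ccc(Cl)cc2)cs1` has a different core, and the difference between the two cores is not broken down here. In this assay compound 3 gives 53200 nM, giving a 1.0-fold lower number from compound 2 to compound 3 (0.02 log units; within the scatter). Compound 4 `CC(C)c1ccc(OCC(=O)Nc2nc(-c3ccc(Cl)cc3)cs2)c(C(C)C)c1` is not yet measured and differs from compound 3 by isopropyl in place of hydrogen on an aromatic carbon. This is the same kind of change as from compound 1 to compound 2, though here the entering group sits meta to an isopropyl group and para to a large group, rather than ortho to a large group. Because the earlier change gave a 1.0-fold higher number from compound 1 to compound 2 (0.00 log units; within the scatter), a similarly flat step a 1.0-fold higher number from compound 3 to compound 4 (0.01 log units; within the scatter) is expected. Compound 4 is therefore estimated at 54000 nM, between 27000 nM and 110000 nM.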

Compound 4, half-maximal inhibitory concentration: 41700 nM
Beside the measured number, compound 4's estimate is 1.3-fold (0.11 log units) above it, within the range that was stated.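

In this assay, isopropyl in place of hydrogen on an aromatic carbon gives a 1.3-fold lower number from compound 3 to compound 4 (0.11 log units; within the scatter), so this step cannot be told apart from the normal variation between repeat measurements. Set beside the earlier step, it shows no difference between the two cores: the same change on two cores in this assay, a 1.0-fold higher number (0.00 log units; within the scatter) from compound 1 to compound 2 and a 1.3-fold lower number (0.11 log units; within the scatter) from compound 3 to compound 4, 1.3-fold (0.11 log units) apart, within the scatter of two such steps. This shows that the change made no clear difference on either core, but two cases with the group entering at different places on the ring do not show that it would behave the same way on other cores.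

Going by these compounds, it remains open whether an amine or a carboxylic acid at this place on the ring would move the number beyond the scatter. On these data alone, whether the same flat result holds in other cell types also remains open.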